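The compounds below may be only part of what the source reports. "The series", "measured", "known", "first", "only" and "open" are said of these compounds alone.

Compound 1 `CCOC(=O)C(=O)CC(=O)/C=C/c1cn(CCC(C)C)c2ccccc12` gives in an assay on isolated protein for inhibition of DNA nucleotidylexotransferase (Homo sapiens), read by scintillation counting, with a stated time of 10 min (on this read-out higher numbers stand for weaker inhibition and lower numbers for stronger inhibition), only a limit, > 40 uM.
Compound 2 `C/C=C/Cn1cc(/C=C/C(=O)CC(=O)C(=O)OCC)c2ccccc21` gives in this assay only a limit, > 40 uM.
Compound 3 `CCOC(=O)C(=O)CC(=O)/C=C/c1cn(Cc2ccccc2)c2ccccc12` gives in this assay only a limit, > 40 uM.

Compound 2 thus stands at the limit of this assay, where all three measured values sit (the limit of > 40 uM in this assay, at which 3 of the 3 values shown sit). Compound 4 `CCOC(=O)C(=O)CC(=O)/C=C/c1cn(Cc2ccc(F)cc2)c2ccccc12` differs from it in one place: 4-fluorophenyl in place of prop-1-en-1-yl on a saturated chain carbon bound to an aromatic nitrogen. The measured steps that bear on this change are a step that the two limits leave unreadable from compound 1 to compound 2, a step that the two limits leave unreadable from compound 1 to compound 3 and a step that the two limits leave unreadable from compound 2 to compound 3. All of them are unreadable; every value is a limit. Among the compounds with values here, no size of step can therefore be read for the change from compound 2 to compound 4, and the expectation is that compound 4 also remains at or near the limit, a step that the limit leaves unreadable from compound 2 to compound 4. Compound 4 is estimated at 60 uM, in the range 25 uM to 200 uM.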

Compound 4, concentration for 50% inhibition: > 40 uM
Compound 4: a limit, no number (the forecaster's own chance of this, stated with the estimate: 80%); the middle value does not contradict the limit.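

In this assay compound 4 gives > 40 uM, which is a limit and not a number. Within the data shown here, no step between compound 4 and compound 1, compound 2 or compound 3 can be read, as all four sit at one limit: the limit of > 40 uM in this assay, at which 4 of the 4 values shown sit. The compounds shown leave open whether any group at this place on the shared core gives a readable inhibition, and how large the differences between such groups would be.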